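This account rests on a few compounds, and the source may have more. Where it says the series, first, only, none or still open, it means among the compounds named here.

Measured compounds:
compound 1 `O=C(O)Cn1c(SCc2ccc(Cl)cc2)nc2ccccc21`: 160 nM
compound 2 `Cc1ccc(CSc2nc3ccccc3n2CC(=O)O)cc1`: 220 nM
compound 3 `COc1ccc(C)cc1CSc1nc2ccccc2n1CC(=O)O`: 1200 nM

In an assay on HEK293 cells for displacement of a labelled ligand from prostaglandin D2 receptor 2 (Homo sapiens) (a lower number here means a stronger inhibitor, a higher number a weaker inhibitor), compound 1 gives 160 nM, compound 2 gives 220 nM, and compound 3 gives 1200 nM. The value of compound 3 stands highest of the three, and its gap to either of the other two is beyond the scatter; the gap between compound 1 and compound 2 is not.

From compound 2 to compound 1 the change is chloro in place of methyl on an aromatic carbon, and the step it made in this assay is a 1.4-fold lower number from compound 2 to compound 1 (0.14 log units; within the scatter). The difference between the core of compound 3 and the core of compound 2 is not broken down here.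

Compound 4 `COc1ccc(Cl)cc1CSc1nc2ccccc2n1CC(=O)O` is not yet measured. It carries the same kind of change relative to compound 3: chloro in place of methyl on an aromatic carbon. The surroundings of the place are not the same as in the earlier pair: in compound 1 the chloro sits para to a large group, in compound 4 it sits meta to a large group and para to a methoxy group.

The step from compound 3 to compound 4 in this assay is expected to be small, a 1.4-fold lower number from compound 3 to compound 4 (0.15 log units; within the scatter). This expectation rests on the step of a 1.4-fold lower number from compound 2 to compound 1 (0.14 log units; within the scatter), which lies within the scatter, and on the starting value of compound 3, 1200 nM. The estimate for compound 4 in this assay is 850 nM. For compound 4 the expected range runs from 400 nM to 1800 nM.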

Compound 4, half-maximal inhibitory concentration: 740 nM
Beside the measured number, compound 4's estimate is 1.1-fold (0.06 log units) above it; the measured number falls inside the stated range.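

Working notes on the chloro-for-methyl change: in this assay the change gives a 1.6-fold lower number from compound 3 to compound 4 (0.21 log units; within the scatter) and so remains a small step on the core of compound 3, as it was on the core of compound 2. Set side by side, the two steps show that the change carried over from one core to the other without a difference that can be told apart from the scatter: the same change on two cores in this assay, a 1.4-fold lower number (0.14 log units; within the scatter) from compound 2 to compound 1 and a 1.6-fold lower number (0.21 log units; within the scatter) from compound 3 to compound 4, 1.2-fold (0.07 log units) apart, within the scatter of two such steps

Among the compounds shown here, this shows only that the exchange leaves the number within the scatter on these two cores; it does not show that chloro and methyl differ from each other in this assay, nor that the same would hold on a core outside this set or with the chloro placed elsewhere on the ring.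

For the compounds shown here, still open is whether another group at this place, such as bromo, trifluoromethyl, nitrile or an amine, would produce a step beyond the scatter, as methyl and chloro are the only two groups compared here. Also open, as far as these compounds go, is how much of the gap between the core of compound 3 and the core of compound 2 belongs to the methoxy group, and whether a hydroxyl or an ethoxy group in its place would narrow that gap.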